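Pyrazole Acids Against Hydroxyacid Oxidase: A Small Change

This account rests on a few compounds, and the source may have more. Where it says the series, first, only, none or still open, it means among the compounds named here.

Measured so far:
compound 1, `Cc1n[nH]c(C(=O)O)c1Cc1ccc(Oc2ccccc2)cc1`, 10%
compound 2, `Cc1n[nH]c(C(=O)O)c1Cc1cccc(-c2ccccc2F)c1`, 5%
compound 3, `CC(C)c1n[nH]c(C(=O)O)c1Cc1cccc(-c2ccc(F)cc2)c1`, 2%

These three compounds share a core, a pyrazole carboxylic acid, and differ in the group hanging from the attached benzyl ring. In an assay on isolated protein for inhibition of 2-Hydroxyacid oxidase 2 (Homo sapiens), tested at 1 uM (on this read-out higher numbers stand for a stronger effect at the one concentration tested and lower numbers for a weaker effect), compound 1 gives 10%, compound 2 gives 5% and compound 3 gives 2%. Compound 2 stands second of the three numbers, but the gaps to compound 3 and to compound 1 both fall within the usual scatter, so the three compounds cannot be told apart on this read-out; all three show only a weak effect.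

Compound 4, `Cc1n[nH]c(C(=O)O)c1Cc1cccc(C#N)c1`, has not yet been measured in this assay. Compared with compound 2 it carries a smaller group: cyano in place of 2-fluorophenyl on an aromatic carbon.

Within the data shown here, no step between two measured compounds helps here, since none of them differ in only one place. The three measured values sit close together and low, so no direction for this change can be read from them. The expectation for the step of no change at the digits printed from compound 2 to compound 4 (within the scatter) is therefore no change beyond the scatter. Compound 4 is estimated at 5%, within a range from 0% to 15%.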

Compound 4, a percentage reported as inhibition, at one concentration (the size of the read-out at that concentration, not a potency): 6%
For compound 4 the middle estimate is 1 percentage points below the measured one; the measured number falls inside the stated range.
By their numbers in this assay, from the lowest: compounds 3, 2, 4 and 1 (each within the scatter of the next).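

In this assay, among these compounds, putting cyano in place of 2-fluorophenyl on an aromatic carbon gives a number 1 percentage points higher from compound 2 to compound 4 (within the scatter), the first comparison here in which two compounds differ in one place only. So at this carbon, meta to a large group, the entering group has 2 heavy atoms, no ring and 1 hydrogen-bond acceptor, the leaving group has 7 heavy atoms and an aromatic ring, and yet the two compounds cannot be told apart on this read-out, with both showing only a weak effect. No measurement here offers an explanation for this result.

As far as these compounds go, what remains open is whether any group on this carbon can lift the read-out clear of the scatter, for instance an amine or a carboxylic acid, each of which differs from both cyano and 2-fluorophenyl. From the compounds shown here alone, it is also open whether the same swap would look equally flat in a compound with a stronger effect, since a comparison between two weak compounds says little about how much this position can matter.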